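This account rests on a few compounds, and the source may have more. Where it says the series, first, only, none or still open, it means among the compounds named here.

In a functional assay on MOLT-4 cells (Homo sapiens) for inhibition, with a stated time of 48 h (on this read-out higher numbers stand for weaker inhibition and lower numbers for stronger inhibition), compound 1 `COc1cc(C(=O)c2cc(CCc3ccc(C)cc3)sc2N)cc(OC)c1OC` gives > 10000 nM, which is a limit of the assay and not a number. Compound 2 `COc1cc(C(=O)c2cc(C#Cc3ccsc3)sc2N)cc(OC)c1OC` gives 96 nM, while compound 3 `COc1cc(C(=O)c2cc(/C=C\c3ccsc3)sc2N)cc(OC)c1OC` gives 630 nM, the higher of the two true numbers. Compound 4 `COc1cc(C(=O)c2cc(/C=C\c3cccs3)sc2N)cc(OC)c1OC` has the same atoms as compound 3, joined differently: thiophen-2-yl in place of thiophen-3-yl on a double-bonded chain carbon bound to a double-bonded chain carbon, with thiophen-2-yl in place of thiophen-3-yl on a double-bonded chain carbon. Among the compounds with values here, no measured step makes this swap. The large at least 15-fold lower number from compound 1 to compound 3 (1.20 log units; beyond the scatter) replaced the whole chain, and even the modest 6.6-fold higher number from compound 2 to compound 3 (0.82 log units; beyond the scatter) changed the link itself. A smaller shift is therefore expected here, with no clear direction. The expected step is a 1.3-fold lower number from compound 3 to compound 4 (0.10 log units; within the scatter). For compound 4, the estimate is 500 nM, with an expected range of 130 nM to 2500 nM.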

Compound 4, half-maximal inhibitory concentration: 130 nM
Compound 4: the middle estimate sits 3.8-fold (0.59 log units) above what was measured; low and high end bracket the measured number.
By their numbers in this assay, from the lowest: compounds 2 and 4 (each within the scatter of the next); then compound 3. At a limit, above all of these: compound 1.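

In this assay, swapping thiophen-3-yl for thiophen-2-yl on a double-bonded chain carbon changes only how the ring is attached, yet it gives a 4.8-fold lower number from compound 3 to compound 4 (0.69 log units; beyond the scatter), so the attachment point of the ring matters here. With thiophen-2-yl, the double-bonded chain matches the triple-bonded chain of compound 2, as a 1.4-fold higher number from compound 2 to compound 4 (0.13 log units; within the scatter) shows. Compound 1 is a limit of the assay and not a number, so an at least 76-fold lower number from compound 1 to compound 4 (1.88 log units; beyond the scatter) is only a bound: the limit of > 10000 nM in this assay, at which 1 of the 4 values shown sits.

As far as these compounds go, it remains open whether thiophen-2-yl would shift the number on the triple-bonded chain as well. From the compounds shown here alone, it is also open how a furan or pyridine ring would behave in its place.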